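From trifluoromethyl to chloro in compound 2

The compounds below may be only part of what the source reports. "The series", "measured", "known", "first", "only" and "open" are said of these compounds alone.

Compound 1 `Oc1ccc(-c2csc(NCc3ccccc3)n2)cc1O`: 2100 nM
Compound 2 `Oc1ccc(-c2csc(NCc3ccccc3C(F)(F)F)n2)cc1O`: 2600 nM
Compound 3 `Oc1ccc(-c2csc(NCc3cccc(C(F)(F)F)c3)n2)cc1O`: 1800 nM

These three compounds share one core and were all tested in a functional assay on B16 cells (Mus musculus) for inhibition; on this read-out higher numbers stand for weaker inhibition and lower numbers for stronger inhibition. In this assay compound 2 gives 2600 nM, a number within the scatter of those of compound 1 and compound 3, so the three cannot be told apart.

The next compound to be tested is compound 4 `Oc1ccc(-c2csc(NCc3ccccc3Cl)n2)cc1O`, which differs from compound 2 in a single group: chloro in place of trifluoromethyl on an aromatic carbon. It carries chloro in place of trifluoromethyl on an aromatic carbon, ortho to a large group.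

Within the data shown here, no measured step makes this exchange directly, and no compound tested so far carries chloro. The closest evidence comes from two steps that put trifluoromethyl in place of hydrogen on an aromatic carbon: a 1.2-fold higher number from compound 1 to compound 2 (0.09 log units; within the scatter) and a 1.2-fold lower number from compound 1 to compound 3 (0.07 log units; within the scatter). Both are small and lie within the scatter, so neither gives a reason to expect a real shift in this assay when the trifluoromethyl of compound 2 is replaced.

The expected change is a 1.2-fold lower number from compound 2 to compound 4 (0.07 log units; within the scatter), which would be no step beyond the scatter. For compound 4 the estimated value is 2200 nM, with an expected range from 1200 nM to 4000 nM.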

Compound 4, half-maximal inhibitory concentration: 2000 nM
Compound 4: middle estimate off by 1.1-fold (0.04 log units), on the high side, and the stated range covers the measured number.
By their numbers in this assay, from the lowest: compounds 3, 4, 1 and 2 (each within the scatter of the next).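

Exchanging trifluoromethyl, with its 4 heavy atoms, for chloro, with its single heavy atom, on this aromatic carbon ortho to a large group gives a 1.3-fold lower number from compound 2 to compound 4 (0.11 log units; within the scatter) in this assay and so leaves the read-out unresolved from that of the earlier compound. Chloro in place of hydrogen on the same carbon gives a 1.1-fold lower number from compound 1 to compound 4 (0.02 log units; within the scatter) and this is also no resolved change, so hydrogen, chloro and trifluoromethyl at this position, which differ clearly in size by heavy-atom count, cannot be told apart on this read-out. No measurement is available that would explain this lack of separation.

The compounds shown leave open whether any group at this position can move the number beyond the scatter, since all three groups tested here carry no hydrogen-bond donors or acceptors, and an amine, a carboxylic acid or a methoxy group would test that question directly. Among these compounds, they also leave open how chloro would behave on the aromatic carbon that bears trifluoromethyl in compound 3, where only that one group is represented so far.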